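From piperidin-1-yl to azetidin-1-yl on the shared core

This account rests on a few compounds, and the source may have more. Where it says the series, first, only, none or still open, it means among the compounds named here.

Values in a functional assay on MGC-803 cells (Homo sapiens) for inhibition, read by sulforhodamine B assay; on this read-out lower numbers stand for stronger inhibition and higher numbers for weaker inhibition:
- compound 1 `O=C1C(Nc2ccccc2F)=CC(=O)c2c1nc1n2[C@H]2OC[C@@H](O)[C@H]2OC1`: 2000 nM
- compound 2 `O=C1C(Nc2ccccc2)=CC(=O)c2c1nc1n2[C@H]2OC[C@@H](O)[C@H]2OC1`: 1830 nM
- compound 3 `O=C1C(N2CCCCC2)=CC(=O)c2c1nc1n2[C@H]2OC[C@@H](O)[C@H]2OC1`: > 4000 nM (a limit, not a number)

Compound 3 stands at > 4000 nM in this assay, which is a limit of the assay and not a number. Its true value is therefore unknown.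

The next compound is compound 4 `O=C1C(N2CCC2)=CC(=O)c2c1nc1n2[C@H]2OC[C@@H](O)[C@H]2OC1`. The change is azetidin-1-yl in place of piperidin-1-yl on a double-bonded ring carbon, with azetidin-1-yl in place of piperidin-1-yl on a double-bonded ring carbon.

Going by the values given here, two measured steps concern this same place. Piperidin-1-yl in place of anilino gave an at least 2.1-fold higher number from compound 2 to compound 3 (0.33 log units; beyond the scatter), and piperidin-1-yl in place of (2-fluorophenyl)amino gave an at least 2.0-fold higher number from compound 1 to compound 3 (0.30 log units; that floor lies within the scatter). The third step, hydrogen in place of fluoro, gave a 1.1-fold lower number from compound 1 to compound 2 (0.04 log units; within the scatter) and is a different kind of change. Among the compounds with values here, no measured step exchanges one non-aromatic ring for another, so the guidance here is only indirect.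

Given an at least 2.1-fold higher number from compound 2 to compound 3 (0.33 log units; beyond the scatter), compound 4, which keeps a non-aromatic ring at that place, is expected to remain close to compound 3 in this assay, with no step beyond the scatter and a real chance of another limit. The estimated step is an at least 1.1-fold lower number from compound 3 to compound 4 (0.05 log units; that floor lies within the scatter) and it is expected to be small. For compound 4 the estimate is 3500 nM, with an expected range from 1500 nM to 8000 nM.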

Compound 4, half-maximal inhibitory concentration: > 16000 nM
Compound 4 ended at the assay's limit (the forecaster's own chance of this, stated with the estimate: 45%); at least 4.5-fold (0.66 log units) between middle value and limit.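

Azetidin-1-yl on this double-bonded ring carbon reads as weaker inhibition in this assay than either aromatic amino group, with an at least 8.7-fold higher number from compound 2 to compound 4 (0.94 log units; beyond the scatter) and an at least 8.0-fold higher number from compound 1 to compound 4 (0.90 log units; beyond the scatter). Compound 3 had left this less certain, since its floor against the fluorinated partner was small, with an at least 2.0-fold higher number from compound 1 to compound 3 (0.30 log units; that floor lies within the scatter), whereas both floors for compound 4 lie beyond the scatter, so in these four compounds each non-aromatic ring gives a higher number than anilino and (2-fluorophenyl)amino. Compound 3 and compound 4 both stop at limits of the assay, not at numbers, so the step between the six-membered and the four-membered ring cannot be read, and neither ring can be ranked above the other.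

On these data alone, how a non-aromatic ring with a second hetero atom, such as morpholine, or an open-chain group such as dimethylamino, would read at this place remains open. Also open, as far as these compounds go, is whether a larger group on the anilino ring, such as methoxy or trifluoromethyl, would move the number beyond the scatter, given that fluoro and hydrogen in compound 1 and compound 2 lie within it.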